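From (morpholin-4-yl)carbonyl to diethylamino on compound 3

The compounds below may be only part of what the source reports. "The series", "measured", "known", "first", "only" and "open" are said of these compounds alone.

Values in a functional assay on HCT-116 cells (Homo sapiens) for inhibition; a higher number here means that more compound is needed for the effect, a lower number that less compound is needed:
- Compound 1 `COc1cc(N2CCNCC2)ccc1Nc1nc(NC2CCCCC2)c2nc[nH]c2n1`: 160 nM
- Compound 2 `COc1cc(N2CCN(CC3CCOC3)CC2)ccc1Nc1nc(NC2CCCCC2)c2nc[nH]c2n1`: 170 nM
- Compound 3 `COc1cc(N2CCC(CC(=O)N3CCOCC3)CC2)ccc1Nc1nc(NC2CCCCC2)c2nc[nH]c2n1`: 70 nM

Compound 3 has the lowest number of the three, at 70 nM, and its gaps to both others lie beyond the scatter. Compound 4 `CCN(CC)CC1CCN(c2ccc(Nc3nc(NC4CCCCC4)c4nc[nH]c4n3)c(OC)c2)CC1` carries diethylamino in place of (morpholin-4-yl)carbonyl on a saturated chain carbon bound to a saturated ring carbon.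

Within the data shown here, no measured step covers this swap. Among the measured compounds shown here, the only single-place step, a 1.1-fold higher number from compound 1 to compound 2 (0.03 log units; within the scatter), adds (oxolan-3-yl)methyl in place of hydrogen on an amine nitrogen in a ring, so it bears on the swap only loosely. It does show that a sizeable addition need not move the number. Compound 4 gives up the group found only in compound 3, so a drift back towards compound 1, at 160 nM, and compound 2, at 170 nM, is the likelier direction in this assay. A small rise is therefore expected, namely a 1.9-fold higher number from compound 3 to compound 4 (0.27 log units; within the scatter). For compound 4 the estimated value is 130 nM, with an expected range of 50 nM to 320 nM.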

Compound 4, half-maximal effective concentration: 55 nM
For compound 4 the middle estimate is 2.4-fold (0.37 log units) above the measured one, within the range that was stated.
By their numbers in this assay, from the lowest: compounds 4 and 3 (each within the scatter of the next); then compounds 1 and 2 (each within the scatter of the next).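

In this assay, the (morpholin-4-yl)carbonyl group of compound 3 can give way to diethylamino with only a 1.3-fold lower number from compound 3 to compound 4 (0.10 log units; within the scatter), so at this place a group with a ring and a carbonyl and a smaller group with neither give numbers that cannot be told apart. The larger exchange on the aromatic carbon does show a modest gain, with 4-((diethylamino)methyl)piperidin-1-yl giving a 3.1-fold lower number from compound 2 to compound 4 (0.49 log units; beyond the scatter) and a 2.9-fold lower number from compound 1 to compound 4 (0.46 log units; beyond the scatter), which places compound 4 clearly below both piperazine-bearing compounds. Nothing measured here explains these differences.

The compounds shown leave open whether the ethyl groups matter, which dimethylamino, pyrrolidin-1-yl or a carboxylic acid on the same carbon would help to test. They also leave open how a longer chain carrying the diethylamino group would behave.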